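Indazole to benzimidazole exchange on the shared core

The compounds below may be only part of what the source reports. "The series", "measured", "known", "first", "only" and "open" are said of these compounds alone.

Measured so far in a functional assay on K562 cells (Homo sapiens) for inhibition, read by trypan blue exclusion, with a stated time of 72 h; a lower number here means a stronger inhibitor, a higher number a weaker inhibitor:
Compound 1 `Cn1c(=O)c(S(=O)(=O)c2ccc(F)cc2)cc2cnc(Nc3ccc4occc4c3)nc21` gives 5000 nM.
Compound 2 `Cn1c(=O)c(S(=O)(=O)c2ccc(F)cc2)cc2cnc(Nc3cccc4[nH]ccc34)nc21` gives 750 nM.
Compound 3 `Cn1c(=O)c(S(=O)(=O)c2ccc(F)cc2)cc2cnc(Nc3ccc4[nH]ncc4c3)nc21` gives 10000 nM.

Compound 3 stands at the highest number of the three in this assay. Against compound 1 the gap is within the scatter, a 2.0-fold higher number from compound 1 to compound 3 (0.30 log units; within the scatter), so no order can be read between these two. Against compound 2 the gap is large and clear, a 13-fold higher number from compound 2 to compound 3 (1.12 log units; beyond the scatter).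

Compound 4 `Cn1c(=O)c(S(=O)(=O)c2ccc(F)cc2)cc2cnc(Nc3ccc4[nH]cnc4c3)nc21` differs from compound 3 only on a nitrogen on an aromatic ring whose other neighbours are aromatic carbon: 1H-benzimidazol-5-yl in place of 1H-indazol-5-yl on a nitrogen on an aromatic ring. The two groups hold the same atoms joined differently, each with one five-membered aromatic ring with 2 hetero atoms, one six-membered aromatic ring of carbon only, 1 hydrogen-bond donor and 1 hydrogen-bond acceptor.

Among the measured compounds shown here, no measured step swaps two bicyclic groups of identical composition. The steps available show that a bicyclic exchange at this position can sit within the scatter, as in a 2.0-fold higher number from compound 1 to compound 3 (0.30 log units; within the scatter), or reach a large size, as in a 13-fold higher number from compound 2 to compound 3 (1.12 log units; beyond the scatter). With the composition unchanged, the expectation is a step of no clear size, a 1.4-fold lower number from compound 3 to compound 4 (0.15 log units; within the scatter), in either direction. Compound 4 is therefore estimated at 7000 nM, with a range from 2500 nM to 20000 nM.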

Compound 4, half-maximal inhibitory concentration: 10000 nM
Estimate against measurement, compound 4: 1.4-fold (0.15 log units) below; measured number inside the range.
By their numbers in this assay, from the lowest: compound 2; then compounds 1, 3 and 4 (each within the scatter of the next).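

Among the compounds shown here, exchanging 1H-indazol-5-yl for 1H-benzimidazol-5-yl on the nitrogen, with the same atoms joined differently, gives in this assay no change at the digits printed from compound 3 to compound 4 (within the scatter) and is the first step to hold composition fixed, so at this position this rearrangement of the five-membered ring does not separate the two compounds. Compound 4 also cannot be told apart from the 1-benzofuran-5-yl compound, with a 2.0-fold higher number from compound 1 to compound 4 (0.30 log units; within the scatter) within the scatter, so compounds 1, 3 and 4 now form one group. The 1H-indol-4-yl compound stands clear of this enlarged group, with a 13-fold higher number from compound 2 to compound 4 (1.12 log units; beyond the scatter) as a large step, but nothing shown explains that gap or the absence of a step between compound 3 and compound 4.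

The step to compound 2 changes both the bicyclic group and its name's point of attachment, so 1H-indol-5-yl and 1H-benzimidazol-4-yl would be needed to tell whether 4-yl attachment or the ring itself tracks with the lower number. Also open, going by these compounds, is whether an amine or a carboxylic acid on the 1H-indol-4-yl group would keep the number of compound 2 in this assay or move it.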